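The source may hold more compounds than are shown below. What is called first, only, known or untested is meant among the compounds shown, and "the series" means these compounds.

Measured in a functional assay on MDA-MB-468 cells (Homo sapiens) for antiproliferative activity, read by MTT assay, with a stated time of 72 h; a lower number here means a stronger inhibitor, a higher number a weaker inhibitor:
- compound 1 `COc1cc(-c2nccn2C)cc(OC)c1OC`: > 100000 nM (a limit of the assay, not a number)
- compound 2 `COc1ccc(-n2ccnc2-c2cc(OC)c(OC)c(OC)c2)cc1[N+](=O)[O-]`: 100 nM
- compound 3 `COc1cc(-c2nccn2-c2cccc(C)c2)cc(OC)c1OC`: 22600 nM

Of the two true numbers, the higher belongs to compound 3, at 22600 nM, so it is the weaker inhibitor of that pair. The next compound, compound 4 `COc1ccc(-n2ccnc2-c2cc(OC)c(OC)c(OC)c2)cc1`, puts 4-methoxyphenyl in place of 3-methylphenyl on an aromatic nitrogen of a five-membered aromatic ring with 2 nitrogen (4-methoxyphenyl in place of 3-methylphenyl on an aromatic nitrogen).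

For the measured compounds named here, only one measured step concerns a change at this nitrogen: an at least 4.4-fold lower number from compound 1 to compound 3 (0.64 log units; beyond the scatter). Its size is open-ended because of the limit of > 100000 nM in this assay, at which 1 of the 3 values shown sits. Going by the values given here, no measured step swaps one aromatic group there for another, so the size of this change has no direct precedent. Still, compound 2 reaches 100 nM with a different aromatic group at this nitrogen, which shows that the number can lie far lower than in compound 3. A lower number in this assay is therefore expected, probably beyond the scatter, though with wide uncertainty. The expected change is a 23-fold lower number from compound 3 to compound 4 (1.35 log units; beyond the scatter). The estimate for compound 4 is 1000 nM, with an expected range from 100 nM to 10000 nM.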

Compound 4, half-maximal inhibitory concentration: 500 nM
Compound 4: middle estimate off by 2.0-fold (0.30 log units), on the high side; the measured number falls inside the stated range.
By their numbers in this assay, from the lowest: compound 2; then compound 4; then compound 3. At a limit, above all of these: compound 1.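

For the compounds shown here, replacing one aromatic group with another on this nitrogen can change the result greatly, which no earlier step could show: in this assay, the change gives a 45-fold lower number from compound 3 to compound 4 (1.66 log units; beyond the scatter), so the identity of the aromatic group matters, not only its presence. Compared with the small methyl group on the same nitrogen, 4-methoxyphenyl gives an at least 200-fold lower number from compound 1 to compound 4 (2.30 log units; beyond the scatter), and this size is open-ended because compound 1 stands at a limit of the assay rather than at a true number: the limit of > 100000 nM in this assay, at which 1 of the 4 values shown sits. Putting hydrogen in place of nitro on an aromatic carbon gives a 5.0-fold higher number from compound 2 to compound 4 (0.70 log units; beyond the scatter), a modest step beside the large one between the two aromatic groups, so a strong result at this nitrogen does not depend entirely on the nitro group.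

3-Methylphenyl and 4-methoxyphenyl differ both in the kind of group they carry and in where it sits, and these two changes cannot be separated with the compounds shown. Going by these compounds, it also remains open how a phenyl group bearing an amine or a carboxylic acid, or a longer chain in place of the aromatic group, would behave on this nitrogen.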